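Swapping the amine side chain on a shared core

The source may hold more compounds than are shown below. What is called first, only, known or untested is meant among the compounds shown, and "the series" means these compounds.

Compound 1 `CN(C)CCn1nc(Cc2ccc(Cl)cc2)c2ccccc2c1=O`: 200 nM
Compound 2 `CN1CCC[C@@H]1Cn1nc(Cc2cccc(F)c2)c2ccccc2c1=O`: 398 nM
Compound 3 `COc1ccc(Cc2nn(C[C@H]3CCCN3C)c(=O)c3ccccc23)cc1OC`: > 1990 nM

Of the compounds shown here, three with a shared core have been tested in an assay for binding affinity to Alpha-1B adrenergic receptor (Homo sapiens); on this read-out lower numbers stand for stronger inhibition and higher numbers for weaker inhibition. Compound 1 gives the lower of the two plain numbers, yet compound 2 sits within the scatter of it, so the two cannot be told apart. Compound 3 reaches only a limit of the assay, (the limit of > 1990 nM in this assay, at which 1 of the 3 values shown sits). Compound 4 `CN1CCC(n2nc(Cc3ccc(Cl)cc3)c3ccccc3c2=O)CC1` has not yet been measured. It differs from compound 1 by 1-methylpiperidin-4-yl in place of 2-(dimethylamino)ethyl on an aromatic nitrogen, on an aromatic nitrogen of the shared core, next to the ring nitrogen. No measured pair shows this exact change, so nothing shown supports a step beyond the scatter in either direction. The expected step from compound 1 is a 1.5-fold higher number from compound 1 to compound 4 (0.18 log units; within the scatter). Compound 4 is therefore estimated at 300 nM, within a range of 100 nM to 1000 nM.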

Compound 4, inhibition constant: 6.31 nM
Beside the measured number, compound 4's estimate is 48-fold (1.68 log units) above it; measured number below the stated range.
By their numbers in this assay, from the lowest: compound 4; then compounds 1 and 2 (each within the scatter of the next). At a limit, above all of these: compound 3.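

For the compounds shown here, this position on the aromatic nitrogen of the shared core responds strongly to the choice of amine side chain, which no earlier pair could show because compounds 1, 2 and 3 differ in more than one place. With the 4-chlorobenzyl group held constant, 1-methylpiperidin-4-yl in place of 2-(dimethylamino)ethyl gives a 32-fold lower number from compound 1 to compound 4 (1.50 log units; beyond the scatter) in this assay. An open chain and a six-membered ring are therefore not interchangeable here.

On these data alone, how a piperidine without its methyl group or a morpholine would behave at this position stays open. Nothing shown explains the size of this step.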